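Swapping the Alkyne Alcohol for a Methoxypyridine Ring

The source may report more compounds than this note shows. Statements on the series, on what has been measured and on what is new or still open speak of the compounds shown alone.

Of the compounds shown here, three sharing one core have been measured in an ADME assay (liver) for metabolic stability, with Liver microsome (Rattus norvegicus) as the target, using microsomes and NADPH, with a stated time of 30 min, tested at 1 uM; a lower number here means slower removal, a higher number faster removal of the compound. Compound 1 `CC(C)(O)C#Cc1cc(C(O)(C(F)(F)F)C(F)(F)F)cnc1N1CCN(S(=O)(=O)c2ccc(N)nc2)CC1` carries a 3-hydroxy-3-methylbut-1-yn-1-yl group and gives 16 mL.min-1.g-1. Compound 2 `Cn1cc(-c2cc(C(O)(C(F)(F)F)C(F)(F)F)cnc2N2CCN(S(=O)(=O)c3ccc(N)nc3)CC2)cn1` gives 44 mL.min-1.g-1, and compound 3 `Nc1ccc(S(=O)(=O)N2CCN(c3ncc(C(O)(C(F)(F)F)C(F)(F)F)cc3-c3ccoc3)CC2)cn1` gives 57 mL.min-1.g-1. Compound 1 therefore stands lowest of the three, meaning it is removed most slowly. The nearest step away from it is a 2.8-fold higher number from compound 1 to compound 2 (0.44 log units; beyond the scatter), and the furthest is a 3.6-fold higher number from compound 1 to compound 3 (0.55 log units; beyond the scatter). The remaining pair shows a 1.3-fold higher number from compound 2 to compound 3 (0.11 log units; within the scatter), so those two cannot be told apart.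

Compound 4 `COc1cncc(-c2cc(C(O)(C(F)(F)F)C(F)(F)F)cnc2N2CCN(S(=O)(=O)c3ccc(N)nc3)CC2)c1` has not yet been measured in this assay. It differs from compound 1 in one place: 5-methoxypyridin-3-yl in place of 3-hydroxy-3-methylbut-1-yn-1-yl on an aromatic carbon. Both measured steps away from compound 1 replaced the same chain with a small aromatic ring, and both raised the number by a modest amount. The change to compound 4 is of the same kind, so a rise of similar size is expected, beyond the scatter but not large. The expected step is a 2.8-fold higher number from compound 1 to compound 4 (0.45 log units; beyond the scatter). Compound 4 is therefore estimated at 45 mL.min-1.g-1, with a range from 22 mL.min-1.g-1 to 90 mL.min-1.g-1.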

Compound 4, intrinsic clearance in microsomes: 58 mL.min-1.g-1
For compound 4 the middle estimate is 1.3-fold (0.11 log units) below the measured one; the range from low to high includes it.
By their numbers in this assay, from the lowest: compound 1; then compounds 2, 3 and 4 (each within the scatter of the next).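

In this assay the 5-methoxypyridin-3-yl ring behaves like the two rings before it at this position, with a 3.6-fold higher number from compound 1 to compound 4 (0.56 log units; beyond the scatter) as the step away from the 3-hydroxy-3-methylbut-1-yn-1-yl chain, the same modest kind of rise. What is new is that a six-membered aromatic ring with one ring nitrogen and a methoxy group cannot be told apart from the furan-3-yl ring, as a 1.0-fold higher number from compound 3 to compound 4 (0.01 log units; within the scatter) shows, or from the 1-methyl-1H-pyrazol-4-yl ring, as a 1.3-fold higher number from compound 2 to compound 4 (0.12 log units; within the scatter) shows. Across these three compounds, the choice of aromatic ring makes no readable difference, and compound 1, the only one with no ring at this position, is the only one that stands apart.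

No measurement shown gives a reason for the gap between the chain and the rings. From the compounds shown here alone, it remains open whether a saturated ring such as morpholine, a simple amine, or a longer chain ending in a hydroxyl group or a carboxylic acid would stay close to compound 1 or fall with the aromatic rings.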